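A few compounds are considered here, and "the series" means these few. Any claim that something is new, unique, unknown or untested is made for them only; others in the source may bear on it.

Measured compounds:
compound 1 `COc1cc(/C=C/C(=O)/C=C(/C=C/c2ccc(O)c(OC)c2)NCCO)ccc1O` — 93.5%
compound 2 `COCCNC(=C\C(=O)/C=C/c1ccc(O)c(OC)c1)/C=C/c1ccc(O)c(OC)c1` — 94%

In an ADME assay on CHO-K1 cells (Cricetulus griseus) for activation, read by fluorescence, tested at 1 uM (a lower number here means a stronger effect, a higher number a weaker effect of the compound at the concentration tested), compound 2 stands at the top of the two numbers, its nearest neighbour being compound 1, yet the step of a number 0.5 percentage points higher from compound 1 to compound 2 (within the scatter) lies within the scatter, so the two compounds are not separated by this read-out. Compound 3 `COCCCNC(=C\C(=O)/C=C/c1ccc(O)c(OC)c1)/C=C/c1ccc(O)c(OC)c1` differs from compound 2 by methoxymethyl in place of methoxy on a saturated chain carbon, two bonds along the chain from an amine nitrogen. Among the compounds with values here, the only measured step that bears on this is the one from compound 1 to compound 2, which also lengthened the same chain on the amine nitrogen by one saturated carbon and gave a number 0.5 percentage points higher from compound 1 to compound 2 (within the scatter), a change within the scatter. On that basis the further lengthening is expected to leave the read-out essentially unchanged, with an expected step of no change at the digits printed from compound 2 to compound 3 (within the scatter) and nothing beyond the scatter. Compound 3 is therefore estimated at 94% in this assay, with a range from 86% to 101%.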

Compound 3, a percentage reported as activity, at one concentration (the size of the read-out at that concentration, not a potency): 98.3%
Estimate against measurement, compound 3: 4.3 percentage points below; low and high end bracket the measured number.
By their numbers in this assay, from the lowest: compounds 1, 2 and 3 (each within the scatter of the next).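

In this assay, methoxymethyl in place of methoxy on a saturated chain carbon, two bonds along the chain from an amine nitrogen, gives a number 4.3 percentage points higher from compound 2 to compound 3 (within the scatter), and methoxymethyl in place of hydroxy at the same place gives a number 4.8 percentage points higher from compound 1 to compound 3 (within the scatter). This read-out therefore separates none of compounds 1, 2 and 3, and the exchange at this position stays within the scatter even for the widest pair shown. No data on why the read-out behaves this way accompany these numbers.

Going by these compounds, whether any group on this chain can give a number beyond the scatter of these three in this assay remains open. A carboxylic acid, an amine or a longer chain carrying the methoxy group would test this.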